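Amino in place of dimethylsulfamoyl: expectation for compound 4

The source may hold more compounds than are shown below. What is called first, only, known or untested is meant among the compounds shown, and "the series" means these compounds.

Compound 3 `CN1CCN(CCCN(C(=O)Nc2ccc(F)c(Cl)c2)C2CCc3ccc(S(=O)(=O)N(C)C)cc3C2)CC1` stands highest of the three numbers in an assay on CHO cells for binding affinity to melanin-concentrating hormone receptor 1 (Homo sapiens) (on this read-out higher numbers stand for weaker inhibition and lower numbers for stronger inhibition), giving 3000 nM; compound 1 `CN1CCN(CCCN(C(=O)Nc2ccc(F)c(Cl)c2)C2CCc3cc(Br)ccc3C2)CC1` gives 180 nM and compound 2 `COc1ccc2c(c1)CC(N(CCCN1CCN(C)CC1)C(=O)Nc1ccc(F)c(Cl)c1)CC2` gives 92 nM, the two of them within the scatter of each other. Compound 4 `CN1CCN(CCCN(C(=O)Nc2ccc(F)c(Cl)c2)C2CCc3ccc(N)cc3C2)CC1` differs from compound 3 by amino in place of dimethylsulfamoyl on an aromatic carbon. Among the compounds with values here, the one measured step that bears on this position is a 33-fold higher number from compound 2 to compound 3 (1.51 log units; beyond the scatter), the entry of dimethylsulfamoyl pushing the number far beyond the scatter. Compound 4 removes that same group again, so a return toward the numbers of compound 1 and compound 2 is expected, though amino is not methoxy and a full return is uncertain. The expected step is a 12-fold lower number from compound 3 to compound 4 (1.08 log units; beyond the scatter). For compound 4 in this assay the estimate is 250 nM, ranging from 70 nM to 900 nM.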

Compound 4, inhibition constant: 260 nM
Compound 4: the middle estimate sits 1.0-fold (0.02 log units) below what was measured, and the stated range covers the measured number.
By their numbers in this assay, from the lowest: compounds 2, 1 and 4 (each within the scatter of the next, the first and the last beyond it); then compound 3.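

In this assay amino in place of dimethylsulfamoyl gives a 12-fold lower number from compound 3 to compound 4 (1.06 log units; beyond the scatter) on this aromatic carbon, so the high number of compound 3 does not hold for every group there. Amino and methoxy are still told apart by a 2.8-fold higher number from compound 2 to compound 4 (0.45 log units; beyond the scatter) in this series. The step of a 1.4-fold higher number from compound 1 to compound 4 (0.16 log units; within the scatter) places compound 4 level with compound 1, though there a 7-amino group replaces a 6-bromo group. On these data alone, whether a carboxylic acid or a dimethylamino group on this aromatic carbon would stay near compound 4 remains open. Nothing available accounts for these differences.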